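The source may hold more compounds than are shown below. What is called first, only, known or untested is meant among the compounds shown, and "the series" means these compounds.

Measured compounds in the series:
compound 1, `COc1ccc(-c2cncnc2-c2cc(OC)c(OC)c(OC)c2)cc1O` — 280 nM
compound 2, `CCOc1ccc(-c2cncnc2-c2cc(OC)c(OC)c(OC)c2)cc1C(F)(F)F` — 790 nM
compound 3, `COc1cc(-c2ncncc2-c2ccc(OCC(F)(F)F)cc2)cc(OC)c1OC` — 10200 nM

All three share the same core and are read in a functional assay on HeLa cells (Homo sapiens) for antiproliferative activity, read by CCK-8 assay, with a stated time of 72 h; a lower number here means a stronger inhibitor, a higher number a weaker inhibitor; in it compound 1 gives 280 nM, the lowest number of the three. Compound 2 gives 790 nM, a higher number that lies beyond the usual scatter, and compound 3 gives 10200 nM, by far the highest number of the set. Both compounds 2 and 3 carry a fluorinated group on the second aryl ring where compound 1 carries the hydroxyl and methoxy groups.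

Compound 4, `COc1cc(-c2ncncc2-c2ccc3cc[nH]c3c2)cc(OC)c1OC`, is not yet measured. It differs from compound 1 in one place: 1H-indol-6-yl in place of 3-hydroxy-4-methoxyphenyl on an aromatic carbon. The entering group keeps one hydrogen-bond donor but brings no acceptor, and a second ring is fused to the six-membered ring.

Going by the values given here, no step between two measured compounds is available for this kind of change. Still, every departure from the 3-hydroxy-4-methoxyphenyl group seen so far, in compounds 2 and 3, gave a higher number. The step of a 3.2-fold higher number from compound 1 to compound 4 (0.51 log units; beyond the scatter) is therefore expected to run upward, by a moderate margin beyond the scatter. For compound 4 in this assay the estimate is 900 nM, with a range from 200 nM to 5000 nM.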

Compound 4, half-maximal inhibitory concentration: 770 nM
Beside the measured number, compound 4's estimate is 1.2-fold (0.07 log units) above it; measured number inside the range.
By their numbers in this assay, from the lowest: compound 1; then compounds 4 and 2 (each within the scatter of the next); then compound 3.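

Going by these compounds alone, replacing 3-hydroxy-4-methoxyphenyl with 1H-indol-6-yl on this aromatic carbon, ortho to a large group, gives in this assay the first single-place step at this position: a 2.8-fold higher number from compound 1 to compound 4 (0.44 log units; beyond the scatter). The step is modest but beyond the scatter, so the position accepts a group with a five-membered aromatic ring and 0 hydrogen-bond acceptors at a limited cost, with compound 4 at 770 nM. No measurement here bears on which feature of the exchange raises the number.

On these data alone, it remains open whether the indole hydrogen on nitrogen matters to the activity, which a methyl group on that nitrogen would test. Also open, as far as these compounds go, is how an aminophenyl or carboxyphenyl group at this position would compare with 3-hydroxy-4-methoxyphenyl.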